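A few compounds are considered here, and "the series" means these few. Any claim that something is new, unique, unknown or untested is made for them only; others in the source may bear on it.

In a functional assay on A549 cells (Homo sapiens) for cytotoxicity, read by MTT assay, with a stated time of 72 h (on this read-out lower numbers stand for stronger inhibition and higher numbers for weaker inhibition), three compounds sharing one core have been measured. Compound 1 (`COc1ccc(/C=C2\CCC/C(=C\c3cccc(Cl)c3)C2=O)cc1OC`) gives 11000 nM. Compound 2 (`COc1cccc(/C=C2\CCC/C(=C\c3ccc(OC)c(OC)c3)C2=O)c1`) gives 6700 nM, and the step between these two is a 1.6-fold lower number from compound 1 to compound 2 (0.22 log units; within the scatter). Compound 3 (`COc1ccc(/C=C2\CCC/C(=C\c3ccc(OC)c(OC)c3)C2=O)cc1`) gives no number, only a limit of the assay: > 20000 nM.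

Compound 4 (`COc1ccc(/C=C2\CCC/C(=C\c3ccc(Cl)c(Cl)c3)C2=O)cc1OC`) differs from compound 3 by 3,4-dichlorophenyl in place of 4-methoxyphenyl on a double-bonded chain carbon bound to a double-bonded ring carbon. The 3,4-dichlorophenyl thus replaces the 4-methoxyphenyl on a double-bonded chain carbon bound to a double-bonded ring carbon.

Two measured steps bring the 4-methoxyphenyl to this same place. One is an at least 1.8-fold higher number from compound 1 to compound 3 (0.25 log units; that floor lies within the scatter), with a 3-chlorophenyl leaving. The other is an at least 2.9-fold higher number from compound 2 to compound 3 (0.47 log units; beyond the scatter), with a 3-methoxyphenyl leaving. Both sizes are floors only, and neither step involves the 3,4-dichlorophenyl itself. Read in reverse, they suggest that losing the 4-methoxyphenyl from this place should give a lower number in this assay, with the firmer support coming from an at least 2.9-fold higher number from compound 2 to compound 3 (0.47 log units; beyond the scatter). The expected change is an at least 2.2-fold lower number from compound 3 to compound 4 (0.34 log units; beyond the scatter), a modest step at the least. The value estimated for compound 4 is 9000 nM, with an expected range of 3500 nM to 20000 nM.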

Compound 4, half-maximal inhibitory concentration: 6900 nM
Compound 4: the middle estimate sits 1.3-fold (0.12 log units) above what was measured; the range from low to high includes it.
By their numbers in this assay, from the lowest: compounds 2, 4 and 1 (each within the scatter of the next). At a limit, above all of these: compound 3.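

In this assay, the 3,4-dichlorophenyl on this double-bonded chain carbon gives a measured number where the 4-methoxyphenyl gave none, with an at least 2.8-fold lower number from compound 3 to compound 4 (0.46 log units; beyond the scatter), and that size is only a floor because compound 3 stands at a limit of the assay: the limit of > 20000 nM in this assay, at which 1 of the 4 values shown sits. The new group does not set compound 4 apart from the two other measured compounds, with a 1.0-fold higher number from compound 2 to compound 4 (0.01 log units; within the scatter) and, for the chloro added to an aromatic carbon, a 1.6-fold lower number from compound 1 to compound 4 (0.20 log units; within the scatter). Among the four compounds, the 4-methoxyphenyl alone stands apart at this place, while the 3-chlorophenyl of compound 1, the 3-methoxyphenyl of compound 2 and the 3,4-dichlorophenyl of compound 4 give numbers within the scatter of one another.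

As far as these compounds go, how far compound 3 really lies from the others remains open, as does whether any group at this place can move the number beyond the scatter of these three. A 4-chlorophenyl would show whether the 4-methoxyphenyl's standing belongs to its methoxy, and a phenyl carrying an amine or a carboxylic acid would test this place with quite different atoms.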